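Swapping the aryl group on the pyridazinone nitrogen

The source may hold more compounds than are shown below. What is called first, only, known or untested is meant among the compounds shown, and "the series" means these compounds.

Measured compounds:
compound 1 `Cc1ccc(-n2nc(C(=O)Nc3ccc(Oc4ncnc5ccsc45)cc3)c(C)cc2=O)cc1`, 23800 nM
compound 2 `Cc1cc(=O)n(-c2ccc(Br)cc2F)nc1C(=O)Nc1ccc(Oc2ncnc3ccsc23)c(F)c1`, 1550 nM
compound 3 `Cc1cc(=O)n(-c2ccccc2OC(F)(F)F)nc1C(=O)Nc1ccc(Oc2ncnc3ccsc23)c(F)c1`, 11500 nM

In a functional assay on MCF7 cells (Homo sapiens) for cytotoxicity, read by MTT assay, with a stated time of 72 h (a lower number here means a stronger inhibitor, a higher number a weaker inhibitor), compound 3 holds the second highest number of the three, between compound 2 and compound 1. Compound 4 `Cc1ccc(-n2nc(C(=O)Nc3ccc(Oc4ncnc5ccsc45)c(F)c3)c(C)cc2=O)cc1` differs from compound 3 by 4-methylphenyl in place of 2-(trifluoromethoxy)phenyl on an aromatic nitrogen. Among the compounds with values here, one measured step bears on this position: a 7.4-fold higher number from compound 2 to compound 3 (0.87 log units; beyond the scatter), showing that the group on that nitrogen shifts the number well beyond the scatter. The same 4-methylphenyl group as in compound 4 is carried by compound 1, which gives 23800 nM in this assay, a higher number than compound 3. Compound 4 is therefore expected to move upward, a 1.7-fold higher number from compound 3 to compound 4 (0.24 log units; within the scatter). The estimate for compound 4 is 20000 nM, with a range from 6000 nM to 60000 nM.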

Compound 4, half-maximal inhibitory concentration: 7250 nM
Estimate against measurement, compound 4: 2.8-fold (0.44 log units) above, and the stated range covers the measured number.
By their numbers in this assay, from the lowest: compound 2; then compounds 4 and 3 (each within the scatter of the next); then compound 1.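

In this assay, replacing 2-(trifluoromethoxy)phenyl with 4-methylphenyl gives a 1.6-fold lower number from compound 3 to compound 4 (0.20 log units; within the scatter) and so does not separate these two groups on the nitrogen. Only 4-bromo-2-fluorophenyl stands apart from 4-methylphenyl here, with a 4.7-fold higher number from compound 2 to compound 4 (0.67 log units; beyond the scatter) for the loss of that group. With 4-methylphenyl held fixed, fluoro in place of hydrogen on an aromatic carbon also counts, giving a 3.3-fold lower number from compound 1 to compound 4 (0.52 log units; beyond the scatter) in this series.

From the compounds shown here alone, whether the bromine or the fluorine of 4-bromo-2-fluorophenyl sets it apart remains open, as does the effect of a pyridyl ring or a cyclohexyl group on that nitrogen. No measured evidence accounts for any of these shifts.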